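This account rests on a few compounds, and the source may have more. Where it says the series, first, only, none or still open, it means among the compounds named here.

Working notes on the series. Compound 1 `Cc1nnc(CN2CCCC2)n1-c1ccc(Cl)cc1C(=O)c1ccccc1` gives 89 mg/kg in a functional assay on the whole organism (strain CF-1) for inhibition, with Mus musculus as the target; on this read-out higher numbers stand for an effect only at larger amounts of compound and lower numbers for an effect already at smaller amounts. Compound 2 `CN(C)Cc1nnc(-c2ccco2)n1-c1ccc(Cl)cc1C(=O)c1ccccc1` gives only a limit in this assay, > 100 mg/kg. Compound 3 `CN(C)Cc1nnc(-c2ccncc2)n1-c1ccc(Cl)cc1C(=O)c1ccccc1Cl` likewise gives only a limit in this assay, namely > 100 mg/kg. Among the compounds with values here, compound 3 thus stands at the limit of > 100 mg/kg in this assay, at which 2 of the 3 values shown sit, and no step between measured compounds can be read from the shared core. Compound 4 `CN(C)Cc1nnc(C2CC2)n1-c1ccc(Cl)cc1C(=O)c1ccccc1Cl` differs from compound 3 in one place: cyclopropyl in place of pyridin-4-yl on an aromatic carbon. Compound 1 carries a methyl on that aromatic carbon and reaches a measurable number, 89 mg/kg, which is the only pointer for a small group there. The expected step is a move out of the limit into the measurable range, an at least 1.1-fold lower number from compound 3 to compound 4 (0.04 log units; that floor lies within the scatter), with the size uncertain. Compound 4 is estimated at 90 mg/kg, with a range from 40 mg/kg to 200 mg/kg, and a fair chance that only a limit is reported again.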

Compound 4, dose for half-maximal effect: 79 mg/kg
Beside the measured number, compound 4's estimate is 1.1-fold (0.06 log units) above it; measured number inside the range.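

In this assay, the change on this aromatic carbon gives an at least 1.2-fold lower number from compound 3 to compound 4 (0.10 log units; that floor lies within the scatter): cyclopropyl yields a measurable number where pyridin-4-yl yields only a limit. The step is a floor and not a measured size, since compound 3 has no number of its own: the limit of > 100 mg/kg in this assay, at which 2 of the 4 values shown sit.

As far as these compounds go, the true size of the step remains open. Also open, from the compounds shown here alone, is whether the ring itself matters, or whether an open chain such as isopropyl, or a plain methyl, on this aromatic carbon in the core of compound 4 would give a similar number.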